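Thiocarbamate series on HCT-116: a dihydroindolyl variant

A few compounds are considered here, and "the series" means these few. Any claim that something is new, unique, unknown or untested is made for them only; others in the source may bear on it.

The series shares a core that carries a thiocarbonyl carbon with a variable amino group. Compound 1 `CC1CCCCN1C(=S)SCc1ccc(C(=O)Nc2ccccc2N)cc1` gives 1320 nM in a functional assay on HCT-116 cells (Homo sapiens) for antiproliferative activity, read by CCK-8 assay, with a stated time of 72 h; a lower number here means a stronger inhibitor, a higher number a weaker inhibitor. Compound 2 `CCN(Cc1ccncc1)C(=S)SCc1ccc(C(=O)Nc2ccccc2N)cc1` gives 750 nM in this assay, and compound 3 `Nc1ccccc1NC(=O)c1ccc(CSC(=S)N2CCN(c3ccncc3)CC2)cc1` gives 540 nM. Among the compounds with values here, the one single-point step so far, a 1.8-fold lower number from compound 1 to compound 2 (0.25 log units; within the scatter), lies within the scatter. Compound 2 therefore sits in the middle of the three numbers, separated from compound 3 and from compound 1 by gaps that are each within the scatter, so no order among the three can be claimed.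

Compound 4 `Nc1ccccc1NC(=O)c1ccc(CSC(=S)N2CCc3cc(Cl)ccc32)cc1` has not yet been measured. It differs from compound 2 as follows: 5-chloro-2,3-dihydro-1H-indol-1-yl in place of ethyl((pyridin-4-yl)methyl)amino on a thiocarbonyl carbon. This change sits at the same thiocarbonyl carbon as the change between compound 1 and compound 2, and that step was small. Within the data shown here, no measured compound carries a bicyclic non-aromatic amine or a chlorine at this position, so the bearing of the only relevant step is limited. The step of a 1.2-fold lower number from compound 2 to compound 4 (0.06 log units; within the scatter) is expected to stay within the scatter, with no direction claimed. Compound 4 is estimated at 650 nM, expected to fall between 250 nM and 1700 nM.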

Compound 4, half-maximal inhibitory concentration: 3210 nM
The estimate for compound 4 lay 4.9-fold (0.69 log units) below the measured number; measured number outside the range, above it.
By their numbers in this assay, from the lowest: compounds 3, 2 and 1 (each within the scatter of the next, the first and the last beyond it); then compound 4.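

At the thiocarbonyl carbon, the amino group can shift the number in this assay beyond the scatter, which the earlier step between compound 1 and compound 2 did not show. Placing 5-chloro-2,3-dihydro-1H-indol-1-yl on this carbon gives a 4.3-fold higher number from compound 2 to compound 4 (0.63 log units; beyond the scatter) and a 2.4-fold higher number from compound 1 to compound 4 (0.39 log units; beyond the scatter), so the penalty appears against both the ethyl((pyridin-4-yl)methyl)amino and the 2-methylpiperidin-1-yl groups and is not tied to a single comparator. No measurement on hand explains why this group raises the number.

The compounds shown do not separate the contribution of the chlorine from that of the 2,3-dihydro-1H-indol-1-yl ring system, and the unsubstituted 2,3-dihydro-1H-indol-1-yl group or a methoxy group in place of the chlorine would address that question. From the compounds shown here alone, it also remains open whether a simple monocyclic amine such as morpholin-4-yl at the thiocarbonyl carbon would stay with the group of compounds 1, 2 and 3 or move towards compound 4.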